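A few compounds are considered here, and "the series" means these few. Any claim that something is new, unique, unknown or untested is made for them only; others in the source may bear on it.

Measured in a physicochemical assay for pharmacokinetics, at pH 8; on this read-out lower numbers stand for a shorter-lived compound and higher numbers for a longer-lived compound:
Compound 1 `CC[C@@H]1C(=O)N(C(C)=O)[C@H]1OC(C)=O`: 2.4 h
Compound 2 `CC[C@@H]1C(=O)N(C(=O)NCc2ccccc2)[C@H]1Oc1ccc(C(=O)O)cc1`: > 80 h

Compound 2 holds the higher of the two read-outs so far. In this assay compound 2 gives > 80 h, which is a limit of the assay and not a number. Compound 3 `CC[C@@H]1C(=O)N(C(C)=O)[C@H]1Oc1ccc(C(=O)O)cc1` differs from compound 2 in one place: methyl in place of benzylamino on a carbonyl carbon, with methyl in place of benzylamino on a carbonyl carbon. Among the compounds with values here, no two measured compounds differ in one place, so this change has no direct precedent here. A shorter half-life, beyond the usual scatter, is nevertheless expected, though its size is uncertain. Within the data shown here, the only exact number comes from compound 1 at 2.4 h, and the expectation leans towards that end. The expected change is an at least 6.6-fold lower number from compound 2 to compound 3 (0.82 log units; beyond the scatter). The estimated half-life of compound 3 is 12 h, with an expected range of 3 h to 50 h.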

Compound 3, half-life: 8.6 h
Compound 3: the middle estimate sits 1.4-fold (0.14 log units) above what was measured; low and high end bracket the measured number.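

In this assay, within the data shown here, the exchange of benzylamino for methyl on a carbonyl carbon gives an at least 9.3-fold lower number from compound 2 to compound 3 (0.96 log units; beyond the scatter), the first direct reading of a change at this position, and it shows that the group held there can move the half-life beyond the usual scatter. With methyl in this place, compound 3 gives 8.6 h, an exact number. The value of compound 2 is a limit of the assay and not a number, so the step gives only a minimum size and the full extent of the change stays unknown: the limit of > 80 h in this assay, at which 1 of the 3 values shown sits.

The compounds shown leave open whether the step follows the aromatic ring or the nitrogen of benzylamino. Also open, on these data alone, is where a simple amino group, a phenyl group or a longer chain on the same carbonyl carbon would fall.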